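Ring-opened diamine in place of ethylpiperazine on the amide

The source may hold more compounds than are shown below. What is called first, only, known or untested is meant among the compounds shown, and "the series" means these compounds.

Working notes on the antagonist series. The series is read in an in vitro functional assay on CHO-CREluc cells for antagonist activity at growth hormone secretagogue receptor type 1 (Homo sapiens), read by a luciferase reporter, with a stated time of 4 h; a lower number here means a stronger inhibitor, a higher number a weaker inhibitor. Compound 1 `CCN1CCN(CC(=O)NC2(c3ccc(Cl)cc3)C(=O)Nc3cc(Cl)c(Cl)cc32)CC1` gives 110 nM in this assay. Compound 3 `CN1CCN(CC(=O)N[C@]2(c3ccc(Cl)cc3)C(=O)Nc3cc(Cl)c(Cl)cc32)CC1` gives 47 nM, a lower number than compound 1, and the gap between them lies beyond the usual scatter; of the two numbers given, compound 1 therefore stands highest. Compound 2 `Cc1cc2c(cc1Cl)NC(=O)C2(NC(=O)CN1CCN(C)CC1)c1ccc(Cl)cc1Cl` gives > 10000 nM, which is a limit of the assay and not a number; this is the limit of > 10000 nM in this assay, at which 1 of the 3 values shown sits. Within the data shown here, no two of the measured compounds differ in one place only, so no single step is measured within the set.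

Compound 4 `CN(C)CCN(C)CC(=O)NC1(c2ccc(Cl)cc2)C(=O)Nc2cc(Cl)c(Cl)cc21` is the next member to be read. Against compound 1 the change is (2-(dimethylamino)ethyl)(methyl)amino in place of 4-ethylpiperazin-1-yl on a saturated chain carbon bound to a carbonyl carbon. The entering chain carries the same count of nitrogen atoms as the ring it replaces, and both groups are without charge and without hydrogen-bond donors, so the expected step from compound 1 to compound 4 is modest, a 1.8-fold higher number from compound 1 to compound 4 (0.26 log units; within the scatter), leaning toward a somewhat higher number but possibly staying within the scatter. Compound 4 is expected to give 200 nM in this assay, between 60 nM and 700 nM.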

Compound 4, half-maximal inhibitory concentration: > 10000 nM
Compound 4: no number, only a limit (the forecaster's own chance of this, stated with the estimate: 10%); middle value at least 50-fold (1.69 log units) away from the limit.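

In this assay, among these compounds, (2-(dimethylamino)ethyl)(methyl)amino in place of 4-ethylpiperazin-1-yl on a saturated chain carbon bound to a carbonyl carbon gives an at least 90-fold higher number from compound 1 to compound 4 (1.95 log units; beyond the scatter) and marks this position as far less tolerant than the earlier compounds could show. The two groups match in nitrogen atoms, hydrogen-bond donors and hydrogen-bond acceptors and both carry no net charge, so these shared counts alone do not preserve the activity of compound 1, while the enters-and-leaves comparison shows the loss of the six-membered ring as the clearest structural difference. The value of compound 4 is a limit of the assay and not a number: the limit of > 10000 nM in this assay, at which 2 of the 4 values shown sit.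

The compounds shown leave open whether the ring itself is what matters, since this single open-chain diamine cannot separate the ring from the spacing and substitution of its nitrogen atoms. A piperidine, a morpholine or a homopiperazine at this position, or an open chain ending in a pyrrolidine, would help to separate these possibilities.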